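Hydroxy in Place of Methoxy: From Compound 2 to Compound 4

A few compounds are considered here, and "the series" means these few. Any claim that something is new, unique, unknown or untested is made for them only; others in the source may bear on it.

Compound 2 `COc1cc(C)cc(-c2nn(CC#N)cc2-c2ccnc(-c3ccc(N(C)C)cc3)c2)c1` was tested in a functional assay on HCT-116 cells (Homo sapiens) for inhibition, read by sulforhodamine B assay, with a stated time of 48 h (on this read-out higher numbers stand for weaker inhibition of growth and lower numbers for stronger inhibition of growth), where compound 2 gives 1640 nM. Among the three compounds measured so far, compound 2 has the second highest number. Its nearest neighbour is compound 1 `COc1cc(C)cc(-c2c(-c3ccnc(-c4ccc(N(C)C)cc4)c3)cnn2CC#N)c1`, which in this assay gives 1030 nM; this difference lies within the scatter of repeated measurements, so no order between compound 1 and compound 2 can be claimed. Furthest from it stands compound 3 `COc1cc(C)cc(-c2nn(CC#N)cc2-c2ccc(-c3cccc(C(C)=O)c3)nc2)c1`, which in this assay gives 10600 nM; that gap lies beyond the scatter, and compound 3 is the weaker of the two. Compound 4 `Cc1cc(O)cc(-c2nn(CC#N)cc2-c2ccnc(-c3ccc(N(C)C)cc3)c2)c1` has not yet been measured. It differs from compound 2 in one place: hydrogen in place of methyl on an oxygen on an aromatic ring. Among the measured compounds shown here, no pair among the measured compounds shows this change, so there is no measured step to lean on. The step of a 1.2-fold higher number from compound 2 to compound 4 (0.09 log units; within the scatter) is expected to be small, within the scatter, with no clear direction. Compound 4 is estimated to give 2000 nM, with a range from 800 nM to 5000 nM.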

Compound 4, concentration for total growth inhibition: 10400 nM
Estimate against measurement, compound 4: 5.2-fold (0.72 log units) below; the measured number lies above the stated range.
By their numbers in this assay, from the lowest: compounds 1 and 2 (each within the scatter of the next); then compounds 4 and 3 (each within the scatter of the next).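

In this assay, the methoxy of the 3-methoxy-5-methylphenyl group turns out not to be a silent place: hydrogen in place of methyl on that oxygen gives a 6.3-fold higher number from compound 2 to compound 4 (0.80 log units; beyond the scatter), a step beyond the scatter towards weaker inhibition of growth. Among the compounds shown here, this is the first measured step, since the earlier compounds held no pair differing in one place. It shows that removing a single carbon atom from this oxygen, with the rest of the structure unchanged, is enough to move the number clearly. Nothing available accounts for this result. The compounds shown leave open whether a longer chain on that oxygen, such as ethoxy, would stay close to compound 2 or move towards compound 4. They also leave open what an amine in place of the hydroxy would give.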